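Trading a Chloro for a Hydroxy Group

A few compounds are considered here, and "the series" means these few. Any claim that something is new, unique, unknown or untested is made for them only; others in the source may bear on it.

Compound 1 `CS(=O)(=O)c1ccc(N2N=C(c3ccc(Br)cc3)CCC2=O)cc1` and compound 2 `CS(=O)(=O)c1ccc(N2N=C(c3ccc(Cl)c(Cl)c3)CCC2=O)cc1` share one core and differ only in the aryl group attached to the carbon that carries a double bond to nitrogen. In a functional assay on the whole organism (strain Wistar) for inhibition, with Rattus norvegicus as the target, read by paw edema, with stated times of 30 min and 3 h, at a dose of 0.05 mmol/kg by the oral route (on this read-out higher numbers stand for more inhibition at the one dose given (going by the name of the read-out) and lower numbers for less inhibition), compound 1 gives 10%, while compound 2 gives 26.6%. Among the measured compounds shown here, that change is a number 16.6 percentage points higher from compound 1 to compound 2 (beyond the scatter), so compound 2 stands highest of the two compounds measured, with compound 1 as its only neighbour and clearly below it. Compound 3 `CS(=O)(=O)c1ccc(N2N=C(c3ccc(O)c(Cl)c3)CCC2=O)cc1` differs from compound 2 in a single place: hydroxy in place of chloro on an aromatic carbon. For the measured compounds named here, no measured step replaces a chloro group by a hydroxy group, so the one step on record, from 4-bromophenyl to 3,4-dichlorophenyl, bears on it only loosely; it shows that changing the aryl substitution can move the read-out by a modest amount. Going by the values given here, with no direct precedent, the expected step of a number 6.6 percentage points lower from compound 2 to compound 3 (within the scatter) is small, with no clear direction beyond the scatter. The estimate for compound 3 in this assay is therefore 20%, with a range from 5% to 40%.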

Compound 3, a percentage reported as inhibition, in the whole organism at one dose (the size of the read-out at that dose, not a potency): 43.3%
Beside the measured number, compound 3's estimate is 23.3 percentage points below it; the whole stated range lies below it.
By their numbers in this assay, from the lowest: compound 1; then compound 2; then compound 3.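

The earlier compounds shown here carried only halogens on this aromatic ring, so they could not show how the read-out responds when a group with a hydrogen-bond donor and acceptor sits para to the large group. In this assay, hydroxy in place of chloro, with the ortho chloro group kept, gives a number 16.7 percentage points higher from compound 2 to compound 3 (beyond the scatter), and compound 3 stands above both other compounds, since the full change of aryl group gives a number 33.3 percentage points higher from compound 1 to compound 3 (beyond the scatter). Thus, among these three compounds, the highest number belongs to the only one without a halogen at this position, although nothing shown explains why this exchange raises the read-out.

From the compounds shown here alone, it remains open whether the gain is specific to hydroxy or would also appear with a methoxy group, an amine or a carboxylic acid at the same position, and whether hydroxy would give a similar result without the chloro group ortho to it. Because each compound is read at a single dose, these numbers also leave open how the compounds would compare at other doses.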